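Swapping the aryl on the amine nitrogen once more

This account rests on a few compounds, and the source may have more. Where it says the series, first, only, none or still open, it means among the compounds named here.

In a functional assay on MCF7 cells (Homo sapiens) for cytotoxicity, read by MTT assay, with a stated time of 48 h (a higher number here means a weaker inhibitor, a lower number a stronger inhibitor), compound 1 `Cc1ccc(S(=O)(=O)/N=C(/CCNC2=CC(=O)c3ccccc3C2=O)Nc2ccc(Cl)cc2)cc1` gives 7080 nM, and compound 2 `Cc1ccc(S(=O)(=O)/N=C(/CCNC2=CC(=O)c3ccccc3C2=O)Nc2ccc(F)c(F)c2)cc1` gives 9420 nM, the higher of the two numbers, though the step of a 1.3-fold higher number from compound 1 to compound 2 (0.12 log units; within the scatter) lies within the scatter. Compound 3 `COc1ccc(N/C(CCNC2=CC(=O)c3ccccc3C2=O)=N\S(=O)(=O)c2ccc(C)cc2)c(OC)c1` differs from compound 2 by 2,4-dimethoxyphenyl in place of 3,4-difluorophenyl on an amine nitrogen. Within the data shown here, the only step that bears on this change is that same aryl swap between compound 1 and compound 2, which stayed within the scatter, so no shift beyond the scatter is expected from the step of a 1.0-fold lower number from compound 2 to compound 3 (0.02 log units; within the scatter). Compound 3 is therefore expected to give 9000 nM, between 3500 nM and 23000 nM.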

Compound 3, half-maximal inhibitory concentration: 30200 nM
Beside the measured number, compound 3's estimate is 3.4-fold (0.53 log units) below it; measured number outside the range, above it.
By their numbers in this assay, from the lowest: compounds 1 and 2 (each within the scatter of the next); then compound 3.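

In this assay the aryl group on this amine nitrogen can move the number beyond the scatter, which the step between compound 1 and compound 2 did not do. The change to 2,4-dimethoxyphenyl brings a 3.2-fold higher number from compound 2 to compound 3 (0.51 log units; beyond the scatter) and a 4.3-fold higher number from compound 1 to compound 3 (0.63 log units; beyond the scatter) as well, so compound 3 is the weakest of the three. Nothing measured here accounts for this shift.

The compounds shown leave open whether both methoxy groups are needed for the step or one alone would give it. They also leave open how an unsubstituted phenyl or a benzyl group on this nitrogen would read.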